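The source may report more compounds than this note shows. Statements on the series, on what has been measured and on what is new or still open speak of the compounds shown alone.

Four closely related imines are compared for their ability to slow the growth of breast cancer cells in a functional assay on MDA-MB-231 cells (Homo sapiens) for antiproliferative activity, read by MTT assay, with a stated time of 48 h; a higher number here means a weaker inhibitor, a lower number a stronger inhibitor. Compound 1, `N#Cc1ncn(-c2ccc(F)cc2)c1/N=C/c1ccc([N+](=O)[O-])cc1`, gives 13400 nM in this assay. Compound 2, `COc1ccc(/C=N/c2c(C#N)ncn2-c2ccc(F)cc2)cc1`, differs from compound 1 by methoxy in place of nitro on an aromatic carbon, and in this assay compound 2 gives 17100 nM, so that a 1.3-fold higher number from compound 1 to compound 2 (0.11 log units; within the scatter). Compound 3, `N#Cc1ncn(Cc2ccc(F)cc2)c1/N=C/c1ccc([N+](=O)[O-])cc1`, keeps the nitro group of compound 1 but carries a different substituent on the ring nitrogen: 4-fluorobenzyl in place of 4-fluorophenyl on an aromatic nitrogen. In this assay compound 3 gives 3440 nM, the lowest of the three numbers, and a 3.9-fold lower number from compound 1 to compound 3 (0.59 log units; beyond the scatter).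

Compound 4, `COc1ccc(/C=N/c2c(C#N)ncn2Cc2ccc(F)cc2)cc1`, has not yet been measured. It differs from compound 3 in the same way that compound 2 differs from compound 1, namely (methoxy in place of nitro on an aromatic carbon); the place lines of the two changes are identical word for word, so this is the same change made on the core of compound 3 rather than on the core of compound 1. Since the step from compound 1 to compound 2 was a 1.3-fold higher number from compound 1 to compound 2 (0.11 log units; within the scatter), the expectation for compound 4 is that its step from compound 3 is of similar size and direction, a 1.3-fold higher number from compound 3 to compound 4 (0.11 log units; within the scatter), resting on that single precedent. On this basis compound 4 is expected to give about 4400 nM in this assay, with a plausible range from 2400 nM to 8500 nM.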

Compound 4, half-maximal inhibitory concentration: 2870 nM
Compound 4: the middle estimate sits 1.5-fold (0.19 log units) above what was measured; the range from low to high includes it.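

On the core of compound 3, methoxy in place of nitro gives a 1.2-fold lower number from compound 3 to compound 4 (0.08 log units; within the scatter) in this assay, and this step matches the one made on the core of compound 1: the same change on two cores in this assay, a 1.3-fold higher number (0.11 log units; within the scatter) from compound 1 to compound 2 and a 1.2-fold lower number (0.08 log units; within the scatter) from compound 3 to compound 4, 1.5-fold (0.18 log units) apart, within the scatter of two such steps. The other change, 4-fluorobenzyl in place of 4-fluorophenyl on an aromatic nitrogen, gives a 6.0-fold lower number from compound 2 to compound 4 (0.78 log units; beyond the scatter), and it also carries over from the nitro pair to the methoxy pair: the same change on two cores in this assay, a 3.9-fold lower number (0.59 log units; beyond the scatter) from compound 1 to compound 3 and a 6.0-fold lower number (0.78 log units; beyond the scatter) from compound 2 to compound 4, 1.5-fold (0.18 log units) apart, within the scatter of two such steps. Across these four compounds, each change therefore has much the same effect on either core: swapping nitro for methoxy makes no difference beyond the scatter, while the 4-fluorobenzyl group gives the lower number with both groups, but this rests on only two cores and one cell line and does not show why either step has the size it has, nor that the agreement would hold on any further core.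

The compounds shown leave open what an amine or a carboxylic acid would give in place of the methoxy or nitro group on the same aromatic carbon. They also leave open whether a longer chain between the aromatic nitrogen and the fluorinated ring would lower the number further or raise it again.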